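A few compounds are considered here, and "the series" means these few. Any claim that something is new, unique, unknown or untested is made for them only; others in the source may bear on it.

Compound 1 `O=C1c2c[n+]([O-])c3ccccc3c2C(=O)c2c1c1ccccc1n2Cc1cn(C[C@@H](O)CO)nn1` is one of three close relatives that share a core and differ only in the group attached to its chain carbon. In a functional assay on HCT-116 cells (Homo sapiens) for cytotoxicity, read by MTT assay, with a stated time of 72 h (a higher number here means a weaker inhibitor, a lower number a stronger inhibitor), compound 1 gives 190 nM. Compound 2 `CC1(C)O[C@@H](CO)[C@H](Cn2cc(Cn3c4c(c5ccccc53)C(=O)c3c[n+]([O-])c5ccccc5c3C4=O)nn2)O1` gives 130 nM in this assay, a change of a 1.5-fold lower number from compound 1 to compound 2 (0.16 log units; within the scatter). Compound 3 `O=C1c2c[n+]([O-])c3ccccc3c2C(=O)c2c1c1ccccc1n2Cc1cn([C@H]2O[C@H](CO)[C@@H](O)[C@H]2O)nn1` gives 710 nM in this assay, a change of a 3.7-fold higher number from compound 1 to compound 3 (0.57 log units; beyond the scatter), and from compound 2 the change is a 5.5-fold higher number from compound 2 to compound 3 (0.74 log units; beyond the scatter). Among these three numbers compound 1 stands second highest, nearest to compound 2 and furthest from compound 3.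

Compound 4 `CCCN1CCN(CCCCn2c3c(c4ccccc42)C(=O)c2c[n+]([O-])c4ccccc4c2C3=O)CC1` has not yet been measured in this assay. Its difference from compound 1 is 3-(4-propylpiperazin-1-yl)propyl in place of 1-(2,3-dihydroxypropyl)-1H-1,2,3-triazol-4-yl on a saturated chain carbon bound to an aromatic nitrogen.

Within the data shown here, none of the measured steps covers this kind of change: each of them swaps one hydroxylated group for another while keeping the triazole, whereas in compound 4 the triazole and its hydroxylated group leave together and a chain bearing a saturated ring with two nitrogens enters. The measured steps only show that varying the group at this position moves the number by a modest amount at most. The size and direction of the step to compound 4 therefore cannot be read from the data, and the expectation is a step of a 1.3-fold lower number from compound 1 to compound 4 (0.10 log units; within the scatter) with wide uncertainty. Compound 4 is expected to give about 150 nM in this assay, somewhere between 35 nM and 650 nM.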

Compound 4, half-maximal inhibitory concentration: 790 nM
Compound 4: the middle estimate sits 5.3-fold (0.72 log units) below what was measured; the whole stated range lies below it.
By their numbers in this assay, from the lowest: compounds 2 and 1 (each within the scatter of the next); then compounds 3 and 4 (each within the scatter of the next).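

In this assay, among these compounds, the change gives a 4.2-fold higher number from compound 1 to compound 4 (0.62 log units; beyond the scatter), and this is the first step in which the triazole itself leaves rather than only the hydroxylated group it carries. It shows that the triazole and its 2,3-dihydroxypropyl group can be replaced by a 3-(4-propylpiperazin-1-yl)propyl chain, with no hydroxyl group and no aromatic ring in the entering group, at a cost beyond the scatter but still modest in size. Compound 4, at 790 nM, also lies within the scatter of compound 3, at 710 nM, so two very different groups at this position end up at a similar number, and nothing measured on these groups explains the rise seen for compound 4.

Because the triazole leaves and the piperazine enters in a single step, the compounds shown cannot say which of the two parts goes with the higher number. A triazole bearing a 4-propylpiperazine would separate the two, while a morpholine or a simple primary amine on the same chain would test whether the piperazine ring matters at all.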